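The source may report more compounds than this note shows. Statements on the series, on what has been measured and on what is new or still open speak of the compounds shown alone.

Three compounds have been measured in a functional assay on CHO cells for antagonist activity at Gonadotropin-releasing hormone receptor (Homo sapiens), read by a luciferase reporter, with a stated time of 30 min; on this read-out higher numbers stand for weaker inhibition and lower numbers for stronger inhibition:

Compound 1, `CCNC(=O)Nc1ccc(-c2nc3n(Cc4c(F)cccc4F)cc(C(=O)OCC)c(=O)n3c2CN(CC(=O)NCc2cn(CCOCCOCCN=[N+]=[N-])nn2)Cc2ccccc2)cc1`, gives 468 nM.
Compound 2, `CCNC(=O)Nc1ccc(-c2nc3n(Cc4c(F)cccc4F)cc(C(=O)OCC)c(=O)n3c2CN(CC(=O)NCc2cn(CCOCCOCCOCCN=[N+]=[N-])nn2)Cc2ccccc2)cc1`, gives 724 nM.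
Compound 3, `CCNC(=O)Nc1ccc(-c2nc3n(Cc4c(F)cccc4F)cc(C(=O)NCc4cn(CCOCCOCCN=[N+]=[N-])nn4)c(=O)n3c2CN(C)Cc2ccccc2)cc1`, gives only a limit of the assay, < 10000 nM.

Compound 1 and compound 2 share one core and differ in a single place: 2-azidoethoxy in place of azido on a saturated chain carbon, two bonds along the chain from an oxygen on a saturated carbon. On this change the half-maximal inhibitory concentration moves by a 1.5-fold higher number from compound 1 to compound 2 (0.19 log units; within the scatter), so the two values cannot be told apart with confidence. For compound 3 the reading is a limit, not a number: the limit of < 10000 nM in this assay, at which 1 of the 3 values shown sits. How the core of compound 3 differs from the core of compound 1 is not broken down here.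

Compound 4, `CCNC(=O)Nc1ccc(-c2nc3n(Cc4c(F)cccc4F)cc(C(=O)NCc4cn(CCOCCOCCOCCN=[N+]=[N-])nn4)c(=O)n3c2CN(C)Cc2ccccc2)cc1`, has not yet been measured. It is built from compound 3 by the same change that leads from compound 1 to compound 2: 2-azidoethoxy in place of azido on a saturated chain carbon, two bonds along the chain from an oxygen on a saturated carbon. In both pairs the change sits at the same place, so it counts as the same change. The step expected from this change is a step that the limit leaves unreadable from compound 3 to compound 4, and that expectation rests on the measured step of a 1.5-fold higher number from compound 1 to compound 2 (0.19 log units; within the scatter), which stayed within the scatter. Because compound 3 shows only the limit < 10000 nM, a limit is also the likely outcome for compound 4. The estimate for compound 4 in this assay is 3000 nM. Its expected range runs from 500 nM to 10000 nM.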

Compound 4, half-maximal inhibitory concentration: < 10000 nM
Compound 4 ended at the assay's limit; the forecaster's own chance of this, stated with the estimate: 60%; the middle value lies beyond the limit too.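

No new step can be read from compound 3 to compound 4, because each of the two compounds gives a limit of the assay and not a number: the limit of < 10000 nM in this assay, at which 2 of the 4 values shown sit.

The compounds shown leave open whether 2-azidoethoxy in place of azido changes the half-maximal inhibitory concentration at all on the core of compound 3, and how strongly compound 3 and compound 4 actually inhibit the receptor.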